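A few compounds are considered here, and "the series" means these few. Any claim that something is new, unique, unknown or untested is made for them only; others in the source may bear on it.

Compound 1 `CCCCOc1ccc(-c2nc3ncccn3c2NC(C)C)cc1` in a toxicity assay on A549 cells (Homo sapiens) for cytotoxicity, read by luminescence and CellTiter-Glo, with a stated time of 48 h (a lower number here means that less compound is tolerated, a higher number that more compound is tolerated), gives 68000 nM. Compound 3 `CCCCOc1ccc(-c2nc3ncccn3c2NCc2ccco2)cc1` in this assay gives 78000 nM, the highest of the two numbers shown, with the nearest step being a 1.1-fold higher number from compound 1 to compound 3 (0.06 log units; within the scatter). For compound 2 `CCCCOc1ccc(-c2nc3ncccn3c2NCc2ccccn2)cc1` this assay reports only a limit, > 100000 nM (the limit of > 100000 nM in this assay, at which 1 of the 3 values shown sits). Compound 4 `CCCCOc1ccc(-c2nc3ncccn3c2NCc2nc[nH]c2C)cc1` differs from compound 3 by 5-methyl-1H-imidazol-4-yl in place of furan-2-yl on a saturated chain carbon bound to a nitrogen on an aromatic ring. The measured steps that bear on this change are an at least 1.2-fold lower number from compound 2 to compound 3 (0.10 log units; that floor lies within the scatter) and a 1.1-fold higher number from compound 1 to compound 3 (0.06 log units; within the scatter), both small, so no step beyond the scatter is expected in this assay for the move to compound 4. Compound 4 is therefore estimated at 85000 nM, within a range from 40000 nM to 150000 nM. The expected step is a 1.1-fold higher number from compound 3 to compound 4 (0.04 log units; within the scatter).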

Compound 4, half-maximal cytotoxic concentration: 100000 nM
Beside the measured number, compound 4's estimate is 1.2-fold (0.07 log units) below it; measured number inside the range.
By their numbers in this assay, from the lowest: compounds 1, 3 and 4 (each within the scatter of the next).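

In this assay, 5-methyl-1H-imidazol-4-yl brings a hydrogen-bond donor that furan-2-yl lacks, and the measured step is a 1.3-fold higher number from compound 3 to compound 4 (0.11 log units; within the scatter). Measured against isopropyl, the (5-methyl-1H-imidazol-4-yl)methyl group gives a 1.5-fold higher number from compound 1 to compound 4 (0.17 log units; within the scatter), so a third group on this nitrogen also stays within the scatter. The remaining step rests on a limit and cannot be read: a number no higher from compound 2 to compound 4 (the limit leaves the size open). That limit belongs to compound 2: the limit of > 100000 nM in this assay, at which 1 of the 4 values shown sits.

The compounds shown leave open whether any group here moves the number beyond the scatter. A carboxylic acid or a primary amine on the chain carbon would test this.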